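Halogen swap on the sulfonamide aryl of a piperazinyl scaffold

The compounds below may be only part of what the source reports. "The series", "measured", "known", "first", "only" and "open" are said of these compounds alone.

Measured compounds:
- compound 1 `COc1ccc(S(=O)(=O)Nc2c(F)cc(Br)cc2F)cc1N1CCNCC1`: 158 nM
- compound 2 `COc1ccc(S(=O)(=O)Nc2cc(Br)cc(Cl)c2Br)cc1N1CCNCC1`: 3.98 nM
- compound 3 `COc1ccc(S(=O)(=O)Nc2cc(Br)cc(Br)c2F)cc1N1CCNCC1`: 2.51 nM

In an assay on isolated protein for binding affinity to 5-hydroxytryptamine receptor 6 (Homo sapiens) (on this read-out higher numbers stand for weaker inhibition and lower numbers for stronger inhibition), compound 3 gives the lowest of the three numbers. Its nearest neighbour is compound 2, the step of a 1.6-fold lower number from compound 2 to compound 3 (0.20 log units; within the scatter) lying within the scatter, so the two cannot be ranked. Its furthest is compound 1, the step of a 63-fold lower number from compound 1 to compound 3 (1.80 log units; beyond the scatter) being large; likewise a 40-fold lower number from compound 1 to compound 2 (1.60 log units; beyond the scatter) is large.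

Compound 4 `COc1ccc(S(=O)(=O)Nc2cc(F)cc(F)c2Cl)cc1N1CCNCC1` arises from compound 3 by the change (2-chloro-3,5-difluorophenyl in place of 3,5-dibromo-2-fluorophenyl on a sulfonamide nitrogen). Going by the values given here, the steps that bear on it are those leaving the aryl of compound 1, where a ring carrying two fluorines and one bromine gave a far higher number than the rings of compound 2 and compound 3, each carrying two bromines and one further halogen. Compound 4 keeps a halogen at each position of the ring of compound 3 but replaces both bromines, so a step toward a higher number in this assay is expected, though one smaller than a 63-fold lower number from compound 1 to compound 3 (1.80 log units; beyond the scatter). The estimate for compound 4 is 15 nM, with a range from 4 nM to 60 nM, a step of a 6.0-fold higher number from compound 3 to compound 4 (0.78 log units; beyond the scatter).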

Compound 4, inhibition constant: 31.6 nM
For compound 4 the middle estimate is 2.1-fold (0.32 log units) below the measured one; the measured number falls inside the stated range.
By their numbers in this assay, from the lowest: compounds 3 and 2 (each within the scatter of the next); then compound 4; then compound 1.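

In this assay the 2-chloro-3,5-difluorophenyl ring, which carries no bromine, gives a 13-fold higher number from compound 3 to compound 4 (1.10 log units; beyond the scatter) and a 7.9-fold higher number from compound 2 to compound 4 (0.90 log units; beyond the scatter) in a second comparison, so among these compounds the two rings carrying two bromines keep the lowest numbers. Yet bromine alone does not set the order: a 5.0-fold lower number from compound 1 to compound 4 (0.70 log units; beyond the scatter) places the bromine-free ring of compound 4 on the lower side of the 4-bromo-2,6-difluorophenyl ring of compound 1, and compound 1 goes against any simple link between bromine and a lower number, showing that the kind of halogen and the way the halogens are arranged on the ring both matter here, although the two cannot be separated. Nothing available gives a measured reason for these steps.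

Every ring shown differs from the others in more than one halogen, so what any single halogen contributes stays open. Also open, going by these compounds, is how a ring bearing a methyl group or a nitrile in place of a halogen would read in this assay on the same sulfonamide nitrogen.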